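Swapping a Halogenated Outer Ring for tert-Butyl

The compounds below may be only part of what the source reports. "The series", "measured", "known", "first", "only" and "open" are said of these compounds alone.

Compound 1 `COC(=O)/C=C/c1cccc(N(Cc2ccc(-c3ccc(F)c(F)c3)cc2)C(=O)C2CCCCC2)c1` and compound 2 `COC(=O)/C=C/c1cccc(N(Cc2ccc(-c3ccc(F)c(Cl)c3)cc2)C(=O)C2CCCCC2)c1` share one core and differ only in a halogen on the outer ring. In an assay on isolated protein with Bile acid receptor (Homo sapiens) as the target (a higher number here means that more compound is needed for the effect, a lower number that less compound is needed), compound 1 gives 72 nM, and compound 2 gives 66 nM. Within the data shown here, the step of a 1.1-fold lower number from compound 1 to compound 2 (0.04 log units; within the scatter) is the only measured change so far. Compound 2 holds the lowest of the two numbers, but compound 1 sits so close that the two cannot be told apart.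

Compound 3 `COC(=O)/C=C/c1cccc(N(Cc2ccc(C(C)(C)C)cc2)C(=O)C2CCCCC2)c1` follows from compound 2 by a larger change: tert-butyl in place of 3-chloro-4-fluorophenyl on an aromatic carbon. Among the measured compounds shown here, the single measured step, a halogen swap on that ring, does not speak to removing the whole 3-chloro-4-fluorophenyl group in favour of tert-butyl, so no measured step bears on it, and the expectation rests on the size of the change alone. Compound 3 is therefore expected to need more compound, a step of a 4.5-fold higher number from compound 2 to compound 3 (0.66 log units; beyond the scatter) in this assay, with wide uncertainty. The estimate for compound 3 is 300 nM, within 80 nM to 1500 nM.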

Compound 3, half-maximal effective concentration: > 1000 nM
Compound 3 was reported as a limit; the forecaster's own chance of this, stated with the estimate: 5%; middle value at least 3.3-fold (0.52 log units) from the limit.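

Compound 3 is reported in this assay only as a limit, not as an exact number: the limit of > 1000 nM in this assay, at which 1 of the 3 values shown sits.

Both an at least 15-fold higher number from compound 2 to compound 3 (1.18 log units; beyond the scatter) and an at least 13-fold higher number from compound 1 to compound 3 (1.14 log units; beyond the scatter) follow when tert-butyl takes the place of the halogenated phenyl ring. Among these compounds, the only earlier change, a swap of one halogen on that ring, stayed within the scatter, so this result is the first to show that the group at this position, para to a large group, can strongly change how much compound is needed.

The compounds shown do not separate the loss of the aromatic ring from the loss of heavy atoms, as the change from compound 2 to compound 3 involves both. A plain phenyl ring or a longer alkyl chain in the same place would bear on that question.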